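This account rests on a few compounds, and the source may have more. Where it says the series, first, only, none or still open, it means among the compounds named here.

Measured compounds in a functional assay on the whole organism (strain C57B/6) with Mus musculus as the target, in the maximal electroshock model; on this read-out lower numbers stand for an effect already at smaller amounts and higher numbers for an effect only at larger amounts of compound:
- compound 1 `CCc1nncn1-c1ccc(OCc2ccccc2)cc1`: 20.8 mg/kg
- compound 2 `CCc1nncn1-c1ccc(OCc2ccccc2Cl)cc1`: 13.2 mg/kg

Among the measured compounds shown here, compound 1 gives the higher of the two numbers; the only other measured compound is compound 2, and the gap is a 1.6-fold lower number from compound 1 to compound 2 (0.20 log units; within the scatter). Compound 3 `CCc1nncn1-c1ccc(OCc2ccc(OC)cc2)cc1` is not yet measured; it differs from compound 1 by methoxy in place of hydrogen on an aromatic carbon. For the measured compounds named here, the one measured step, a 1.6-fold lower number from compound 1 to compound 2 (0.20 log units; within the scatter), concerns chloro rather than methoxy and stays within the scatter, so nothing in the data points to a step beyond the scatter from compound 1 to compound 3 in this assay. For compound 3 the expected value is 18 mg/kg (range 9 mg/kg to 40 mg/kg), which corresponds to an expected step of a 1.2-fold lower number from compound 1 to compound 3 (0.06 log units; within the scatter).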

Compound 3, dose for half-maximal effect: 15.8 mg/kg
Estimate against measurement, compound 3: 1.1-fold (0.06 log units) above, within the range that was stated.
By their numbers in this assay, from the lowest: compounds 2, 3 and 1 (each within the scatter of the next).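

In this assay, methoxy para to a large group gives a 1.3-fold lower number from compound 1 to compound 3 (0.12 log units; within the scatter). Among the compounds shown here, this place on the aromatic ring thus accepts a group of 2 heavy atoms with 1 hydrogen-bond acceptor, with no step beyond the scatter, whereas the earlier compounds gave no reading for this change. No supporting data bear on this result.

On these data alone, whether an amine, a carboxylic acid or a longer chain at this place would give a step beyond the scatter remains open. So does whether methoxy elsewhere on this ring would stay within it.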